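A few compounds are considered here, and "the series" means these few. Any claim that something is new, unique, unknown or untested is made for them only; others in the source may bear on it.

Measured compounds in a functional assay on the whole organism for inhibition, with Digitaria ciliaris as the target, with a stated time of 72 h, tested at 10 mg/L; a higher number here means more inhibition of growth at the concentration tested, a lower number less inhibition of growth:
Compound 1 `CSc1cc(C)nc(NC(=S)NC(=O)c2c(-c3ccc(Cl)cc3Cl)noc2C)n1` gives 26.7%.
Compound 2 `Cc1cc(Cl)nc(NC(=S)NC(=O)c2c(-c3ccc(Cl)cc3Cl)noc2C)n1` gives 10.2%.
Compound 3 `COc1cc(Cl)nc2n/c(=N/C(=O)c3c(-c4ccc(Cl)cc4Cl)noc3C)sn12` gives 16.5%.

Compounds 1 and 2 share a core and differ in one place, (methylsulfanyl in place of chloro on an aromatic carbon), and this change made a step of a number 16.5 percentage points higher from compound 2 to compound 1 (beyond the scatter). Compound 3 carries a different core; the difference between the two cores is not broken down here, and in this assay compound 3 and compound 2 lie within the scatter of each other. Compound 4 `COc1cc(SC)nc2n/c(=N/C(=O)c3c(-c4ccc(Cl)cc4Cl)noc3C)sn12` has not been measured. It differs from compound 3 by methylsulfanyl in place of chloro on an aromatic carbon. This is the same kind of change as that from compound 2 to compound 1, not the same one: here the ring is part of a fused or bridged system of two rings, the position is meta to a fused ring, meta to a methoxy group and para to a fused ring, whereas in compound 1 it is meta to a large group and meta to a methyl group. On the strength of the step seen from compound 2 to compound 1, compound 4 is expected to be higher than compound 3 by about a number 12.5 percentage points higher from compound 3 to compound 4 (beyond the scatter). The estimate for compound 4 in this assay is 29%, with a range from 13% to 45%.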

Compound 4, percent growth inhibition at one concentration: 19.8%
Beside the measured number, compound 4's estimate is 9.2 percentage points above it; the range from low to high includes it.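

Placing methylsulfanyl where chloro stood on the core of compound 3 gave, in this assay, a number 3.3 percentage points higher from compound 3 to compound 4 (within the scatter), so on this core the two values cannot be told apart. Set beside the earlier step on the core of compound 1, the new step does not differ from it by more than the scatter allows: the same change on two cores in this assay, a number 16.5 percentage points higher (beyond the scatter) from compound 2 to compound 1 and a number 3.3 percentage points higher (within the scatter) from compound 3 to compound 4, 13.2 percentage points apart, within the scatter of two such steps This shows no clear sign that the core alters the effect of the change, but it does not show that the effect carries over, since only one of the two steps lies beyond the scatter and a single pair on each core cannot separate a real dependence on the core from scatter.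

The compounds shown leave open how other groups at this position, such as an amine or a longer sulfur-linked chain like ethylsulfanyl, would behave on either core. They also leave open whether any such replacement would give a step beyond the scatter on both cores.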